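Trading Cyclopropylmethyl for Methoxy on the Shared Core

The source may report more compounds than this note shows. Statements on the series, on what has been measured and on what is new or still open speak of the compounds shown alone.

Going by the values given here, compound 2 `Cc1c(Oc2ccccc2OCCn2ccc(=O)[nH]c2=O)cc(CC2CC2)c2ccc(C#N)cc12` is the only compound here with a number rather than a limit in a toxicity assay on MT2 cells (Homo sapiens) for cytotoxicity, read by MTT assay (a higher number here means that more compound is tolerated, a lower number that less compound is tolerated), where compound 2 gives 13000 nM. Compound 1 `Cc1cc(Oc2ccccc2OCCn2ccc(=O)[nH]c2=O)c(C)c2cc(C#N)ccc12` reaches only a limit in this assay, giving > 100000 nM. Among the compounds with values here, the single measured step, an at least 7.6-fold lower number from compound 1 to compound 2 (0.88 log units; beyond the scatter), starts from the limit of > 100000 nM in this assay, at which 1 of the 2 values shown sits. Compound 3 `COc1cc(Oc2ccccc2OCCn2ccc(=O)[nH]c2=O)c(C)c2cc(C#N)ccc12` differs from compound 2 by methoxy in place of cyclopropylmethyl on an aromatic carbon. This change takes away the cyclopropyl that entered in an at least 7.6-fold lower number from compound 1 to compound 2 (0.88 log units; beyond the scatter), so the number is expected to climb back toward the limit. Compound 3 is therefore estimated to give 60000 nM, between 20000 nM and 150000 nM, an expected step of a 4.6-fold higher number from compound 2 to compound 3 (0.66 log units; beyond the scatter).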

Compound 3, half-maximal cytotoxic concentration: > 100000 nM
Compound 3 was reported as a limit; the forecaster's own chance of this, stated with the estimate: 40%; at least 1.6-fold (0.22 log units) between middle value and limit.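

Methoxy in place of cyclopropylmethyl on this aromatic carbon gives an at least 7.6-fold higher number from compound 2 to compound 3 (0.88 log units; beyond the scatter) in this assay, so among the compounds shown, a number under the limit appears only with cyclopropylmethyl. Compound 3 joins compound 1 at the limit, and the step between those two cannot be read. Most of the set now stands at that limit: the limit of > 100000 nM in this assay, at which 2 of the 3 values shown sit.

On these data alone, whether an amine or a longer chain on this carbon would also bring the number under the limit stays open. So does how much compound 1 and compound 3 differ.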